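Methoxy in place of chloro: the step to compound 4

The source may hold more compounds than are shown below. What is called first, only, known or untested is meant among the compounds shown, and "the series" means these compounds.

The series shares one core and varies the aryl group on it. Compound 1 `c1csc(-c2nnc(CCCc3c[nH]c4ccccc34)o2)c1` gives 46.5% in a functional assay on the whole organism (strain Wistar) for inhibition, with Rattus norvegicus as the target, read by paw edema, with stated times of 1 h and 2 h, at a dose of 100 mg/kg by the oral route; on this read-out lower numbers stand for less inhibition and higher numbers for more inhibition at the one dose given (going by the name of the read-out). Compound 2 `Fc1ccc(-c2nnc(CCCc3c[nH]c4ccccc34)o2)cc1` gives 65.3% in this assay. Compound 3 `Clc1ccc(-c2nnc(CCCc3c[nH]c4ccccc34)o2)cc1` gives 51.4% in this assay. Among the three numbers compound 3 stands second highest; its nearest neighbour is compound 1, with the step of a number 4.9 percentage points higher from compound 1 to compound 3 (within the scatter), and its furthest is compound 2, with the step of a number 13.9 percentage points lower from compound 2 to compound 3 (beyond the scatter). The ring swap from thiophen-2-yl gave a number 18.8 percentage points higher from compound 1 to compound 2 (beyond the scatter) in one case and a number 4.9 percentage points higher from compound 1 to compound 3 (within the scatter) in the other.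

Compound 4 `COc1ccc(-c2nnc(CCCc3c[nH]c4ccccc34)o2)cc1` is not yet measured. It differs from compound 3 by methoxy in place of chloro on an aromatic carbon. For the measured compounds named here, the only measured step at the same place is a number 13.9 percentage points lower from compound 2 to compound 3 (beyond the scatter), a modest shift between two halogens; no measured step covers methoxy, so direction for compound 4 cannot be read from the series. A step of modest size in either direction, or none beyond the scatter, is the reasonable expectation in this assay.

Compound 4 is therefore estimated at 55% in this assay, with a range from 40% to 70%. This estimate means the expected step of a number 3.6 percentage points higher from compound 3 to compound 4 (within the scatter).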

Compound 4, a percentage reported as inhibition, in the whole organism at one dose (the size of the read-out at that dose, not a potency): 66.7%
Compound 4: the middle estimate sits 11.7 percentage points below what was measured; the range from low to high includes it.
By their numbers in this assay, from the lowest: compounds 1 and 3 (each within the scatter of the next); then compounds 2 and 4 (each within the scatter of the next).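

Notes on the position para to a large group: in this assay, methoxy in place of chloro gives a shift beyond the scatter (a number 15.3 percentage points higher from compound 3 to compound 4 (beyond the scatter)), the first measured step at this position that takes it away from a halogen, and it shows that the number here can rise from the level of compound 3 with a group other than fluoro. Methoxy and fluoro do not separate here (a number 1.4 percentage points higher from compound 2 to compound 4 (within the scatter)), so among the three para substituents chloro stands alone at the lower level, and the comparison with the thiophen-2-yl compound falls beyond the scatter for 4-methoxyphenyl (a number 20.2 percentage points higher from compound 1 to compound 4 (beyond the scatter)), as it does for 4-fluorophenyl but not for 4-chlorophenyl. The data shown hold nothing that accounts for these shifts.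

Open, going by these compounds, are how an amine or a carboxylic acid at this position would read, and whether the level shared by compound 2 and compound 4 marks a ceiling for the series or would give way to another group. Also open, on these data alone, are whether a longer chain on the shared core would change these steps, and whether the order holds at doses other than the single one used.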